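Methoxy on the aryl ring of a pyranone styryl series

The compounds below may be only part of what the source reports. "The series", "measured", "known", "first", "only" and "open" are said of these compounds alone.

Three compounds of the series have numbers in an ADME assay on HaCaT cells (Homo sapiens) for inhibition, read by sulforhodamine B assay, with a stated time of 48 h; on this read-out higher numbers stand for weaker inhibition of growth and lower numbers for stronger inhibition of growth. Compound 1 `COc1ccc(/C=C/C2CC(=O)C=CO2)cc1` gives 145 uM in this assay. Compound 2 `COc1cc(/C=C/C2CC(=O)C=CO2)cc(OC)c1OC` gives 155 uM in this assay, a number within the scatter of that of compound 1. Compound 3 `O=c1ccoc(/C=C/c2ccccc2)c1` gives 711 uM in this assay, the highest of the three numbers: the gap to compound 2 and the gap to compound 1 both lie beyond the scatter, so compound 3 inhibits growth most weakly of the three. Going by the values given here, compound 1 and compound 2 differ from compound 3 in more than one place, so no single step between measured compounds is available.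

Compound 4 `COc1ccc(/C=C/c2cc(=O)cco2)cc1` is not yet measured in this assay. It differs from compound 3 by methoxy in place of hydrogen on an aromatic carbon. The measured compounds that carry a methoxy group, compound 1 and compound 2, have the lower numbers, but they also differ from compound 3 in their core, so the share of the methoxy group in that gap is not separable. A step from compound 3 to compound 4 that lowers the number is expected, of moderate size, and likely beyond the scatter, though a step within the scatter cannot be excluded; the expected step is a 2.0-fold lower number from compound 3 to compound 4 (0.31 log units; beyond the scatter). For compound 4 the estimated value in this assay is 350 uM, with a range from 150 uM to 800 uM.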

Compound 4, concentration for growth inhibition (reported as GI): 710 uM
Beside the measured number, compound 4's estimate is 2.0-fold (0.31 log units) below it; the range from low to high includes it.
By their numbers in this assay, from the lowest: compounds 1 and 2 (each within the scatter of the next); then compounds 4 and 3 (each within the scatter of the next).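

Placing methoxy in place of hydrogen on the aromatic carbon, para to a group of 9 heavy atoms, gives in this assay a 1.0-fold lower number from compound 3 to compound 4 (0.00 log units; within the scatter), the first single-place reading in the series. On the core of compound 3, this one change therefore leaves the number within the scatter, so the presence of a methoxy group cannot by itself be taken to account for the values of compound 1 and compound 2, whose cores differ from that of compound 3 and which carry the group as well. No available data bear on why this step is so small.

On these data alone, whether a different group at this place, such as an amine, a carboxylic acid or a longer alkoxy chain, would move the number on the core of compound 3 stays open. Also open, as far as these compounds go, are what a methoxy group would do elsewhere on the aromatic ring of this core, and whether a hydrogen in place of methoxy would change the number on the core of compound 1.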